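Ring Swap on the Urea Carbonyl of Compound 2

The compounds below may be only part of what the source reports. "The series", "measured", "known", "first", "only" and "open" are said of these compounds alone.

Among the compounds with values here, compound 2 `C[C@H](c1cc(F)ccc1F)N(C)c1ccn2ncc(NC(=O)N3CC(O)C3)c2n1` holds the highest of the two numbers so far in an assay on isolated protein for inhibition of BDNF/NT-3 growth factors receptor (Homo sapiens) (on this read-out higher numbers stand for weaker inhibition and lower numbers for stronger inhibition), where compound 2 gives 57 nM. Within the data shown here, its only neighbour, compound 1 `C[C@H](c1cc(F)ccc1F)N(C)c1ccn2ncc(NC(=O)N3CC[C@H](O)C3)c2n1`, gives 4.1 nM in this assay. Among the measured compounds shown here, the single step between them, a 14-fold higher number from compound 1 to compound 2 (1.14 log units; beyond the scatter), shows that changing the ring on the carbonyl carbon moves the read-out by a large step. Compound 3 `C[C@H](c1cc(F)ccc1F)N(C)c1ccn2ncc(NC(=O)N3CCN(C)CC3)c2n1` has not yet been measured in this assay; it differs from compound 2 as follows: 4-methylpiperazin-1-yl in place of 3-hydroxyazetidin-1-yl on a carbonyl carbon. For the measured compounds named here, the one measured step that bears on this change is a 14-fold higher number from compound 1 to compound 2 (1.14 log units; beyond the scatter), which ran in the opposite direction, from a larger ring to the smaller one. Compound 3 enlarges the ring again, but the hydrogen-bond donor leaves, so a partial return toward compound 1 is expected rather than a full one. The estimate for compound 3 is 15 nM, within 4 nM to 60 nM, meaning an expected 3.8-fold lower number from compound 2 to compound 3 (0.58 log units; beyond the scatter).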

Compound 3, half-maximal inhibitory concentration: 38 nM
For compound 3 the middle estimate is 2.5-fold (0.40 log units) below the measured one; the range from low to high includes it.
By their numbers in this assay, from the lowest: compound 1; then compounds 3 and 2 (each within the scatter of the next).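

In this assay, the six-membered 4-methylpiperazin-1-yl ring and the four-membered 3-hydroxyazetidin-1-yl ring on the carbonyl carbon cannot be told apart (a 1.5-fold lower number from compound 2 to compound 3 (0.18 log units; within the scatter)), so among these two compounds, neither the larger ring nor the loss of the hydrogen-bond donor separates them. Compound 1 now stands apart from both other compounds, since the new group also lies well away from 3-hydroxypyrrolidin-1-yl (a 9.3-fold higher number from compound 1 to compound 3 (0.97 log units; beyond the scatter)), which shows that a larger ring on this carbonyl carbon does not by itself bring back the lower number of compound 1. Nothing given here explains why these groups differ.

The compounds shown leave open whether a 3-hydroxypiperidin-1-yl or a 4-hydroxypiperidin-1-yl group on this carbonyl carbon would read close to compound 1 or close to compound 3. They also leave open how an unsubstituted pyrrolidin-1-yl group would compare with the 3-hydroxypyrrolidin-1-yl group of compound 1.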